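The source may report more compounds than this note shows. Statements on the series, on what has been measured and on what is new or still open speak of the compounds shown alone.

Working notes on the series, all read in a functional assay for inhibition, with Rattus norvegicus as the target; on this read-out higher numbers stand for weaker inhibition and lower numbers for stronger inhibition. Compound 1 `CC(/N=c1\c(O)c(O)\c1=N/c1ccc(S(C)(=O)=O)cc1)C(C)(C)C` gives only a limit, > 30000 nM. Going by the values given here, compound 2 `CC(C)/N=c1\c(O)c(O)\c1=N/c1ccc(C#N)cc1` gives 13700 nM, the only actual number so far, so its standing cannot yet be judged against a second measured value. Compound 3 `C[C@@H](/N=c1\c(O)c(O)\c1=N/c1ccc(C#N)cc1)C1CCCCC1` differs from compound 2 at one place: 1-cyclohexylethyl in place of isopropyl on a double-bonded nitrogen, with 1-cyclohexylethyl in place of isopropyl on a double-bonded nitrogen. Among the compounds with values here, no measured step covers this change, so the expectation is a judgement that starts from compound 2 at 13700 nM. A move beyond the scatter towards lower numbers in this assay is expected, though with wide uncertainty. The estimated size of the move is a 7.6-fold lower number from compound 2 to compound 3 (0.88 log units; beyond the scatter). For compound 3 the expected value is 1800 nM, with an estimated range of 250 nM to 11000 nM.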

Compound 3, half-maximal inhibitory concentration: 2600 nM
Beside the measured number, compound 3's estimate is 1.4-fold (0.16 log units) below it; the range from low to high includes it.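

In this assay, going by these compounds alone, the group on the double-bonded nitrogen turns out to matter for the read-out, giving the first measured step: a 5.3-fold lower number from compound 2 to compound 3 (0.72 log units; beyond the scatter). With the rest of the structure held constant, 1-cyclohexylethyl in place of isopropyl moves the number towards stronger inhibition, so a group with one six-membered non-aromatic ring of carbon only can stand at this place without loss. Compound 1 remains a limit of the assay and not a number, and it differs from the other compounds in more than one place, so no step can be read from it: the limit of > 30000 nM in this assay, at which 1 of the 3 values shown sits.

On these data alone, it remains open whether the change in the number follows the ring itself or the defined stereocentre, and how the opposite configuration would read. Also open, as far as these compounds go, is how a phenyl ring in place of the cyclohexyl ring, or an amine on that ring, would read.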